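A few compounds are considered here, and "the series" means these few. Any claim that something is new, unique, unknown or untested is made for them only; others in the source may bear on it.

Working notes on the series, read in a functional assay on HeLa cells (Homo sapiens) for inhibition, read by MTT assay, with a stated time of 48 h; on this read-out higher numbers stand for weaker inhibition and lower numbers for stronger inhibition. For the measured compounds named here, compound 1 `COc1ccc(/C=C/C(=O)NO)cc1OCC(=O)Nc1ccc(Cl)c(Cl)c1` gives 13400 nM, and compound 2 `COc1ccc(/C=C/C(=O)NO)cc1OCC(=O)Nc1ccccc1F` gives 3910 nM, so compound 2 holds the lower of the two numbers so far. Next in line is compound 3 `COc1ccc(/C=C/C(=O)NO)cc1OCC(=O)Nc1cccc(F)c1`, which keeps the shared core of compound 2 and differs only in the fluorophenyl group: 3-fluorophenyl in place of 2-fluorophenyl on an amide-type nitrogen. In words, 3-fluorophenyl stands in place of 2-fluorophenyl on an amide-type nitrogen.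

Going by the values given here, only one measured step bears on this change: a 3.4-fold lower number from compound 1 to compound 2 (0.53 log units; beyond the scatter). That step is modest, and it replaced 3,4-dichlorophenyl with 2-fluorophenyl, a larger change than the present one, where the same atoms are only joined differently. Among the compounds with values here, no measured pair isolates the place of the fluorine, so the direction remains open. A smaller step than that one is therefore expected, most likely none beyond the scatter. The expected step is a 1.2-fold higher number from compound 2 to compound 3 (0.06 log units; within the scatter). For compound 3 the estimated value is 4500 nM, with an expected range of 2000 nM to 10000 nM.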

Compound 3, half-maximal inhibitory concentration: 6480 nM
Estimate against measurement, compound 3: 1.4-fold (0.16 log units) below; low and high end bracket the measured number.
By their numbers in this assay, from the lowest: compounds 2 and 3 (each within the scatter of the next); then compound 1.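

In this assay, for the compounds shown here, 3-fluorophenyl in place of 2-fluorophenyl on the amide-type nitrogen gives a 1.7-fold higher number from compound 2 to compound 3 (0.22 log units; within the scatter) and this is the first measured pair that isolates the place of the fluorine, which so far shows no effect that can be told from the scatter. The separation from compound 1 holds for both fluorophenyl groups, with a 2.1-fold lower number from compound 1 to compound 3 (0.32 log units; beyond the scatter) now standing alongside a 3.4-fold lower number from compound 1 to compound 2 (0.53 log units; beyond the scatter) in the series. Each of those two steps replaces 3,4-dichlorophenyl as a whole, however, so the kind of halogen and the number of halogens remain tied together, and no measured evidence on the origin of any of these numbers is at hand.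

Still open is how 4-fluorophenyl on the same amide-type nitrogen compares with the two fluorophenyl groups shown, and whether plain phenyl stands with them or with 3,4-dichlorophenyl. Also open, from the compounds shown here alone, is whether 3-chlorophenyl follows 3-fluorophenyl, which would begin to separate chlorine against fluorine from the count of halogens, and whether a group of another kind, such as 3-aminophenyl, shifts the number at all.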